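Adding a chloro group next to the trifluoromethyl of compound 3

This account rests on a few compounds, and the source may have more. Where it says the series, first, only, none or still open, it means among the compounds named here.

Of the compounds shown here, three sharing one core have been measured in a functional assay on CCRF-CEM cells (Homo sapiens) for inhibition, read by sulforhodamine B assay, with a stated time of 48 h, tested at 10 uM; on this read-out lower numbers stand for a stronger effect and higher numbers for a weaker effect at the one concentration tested. Compound 1 `COc1cc2cc(Oc3ccc(NC(=O)Nc4ccccc4)cc3)c(C)nc2cc1OC` gives 55.3%. Compound 2 `COc1cc2cc(Oc3ccc(NC(=O)Nc4ccc(C(F)(F)F)cc4)cc3)c(C)nc2cc1OC` gives 68.5%, and compound 3 `COc1cc2cc(Oc3ccc(NC(=O)Nc4cccc(C(F)(F)F)c4)cc3)c(C)nc2cc1OC` gives 6.41%. Compound 3 stands lowest of the three, with compound 1 nearest and compound 2 furthest. The measured steps were a number 13.2 percentage points higher from compound 1 to compound 2 (beyond the scatter), a number 48.9 percentage points lower from compound 1 to compound 3 (beyond the scatter) and a number 62.1 percentage points lower from compound 2 to compound 3 (beyond the scatter), so the position of the trifluoromethyl group made a large difference in this assay.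

Compound 4 `COc1cc2cc(Oc3ccc(NC(=O)Nc4ccc(Cl)c(C(F)(F)F)c4)cc3)c(C)nc2cc1OC` is to be measured next. It differs from compound 3 by chloro in place of hydrogen on an aromatic carbon. Within the data shown here, none of the measured steps involves a chloro group, so no direct precedent exists for this change; the 3-(trifluoromethyl)phenyl pattern of compound 3 is kept. Given that compound 3 gives 6.41%, compound 4 is expected to stay in the same low region, with a step of a number 3.6 percentage points higher from compound 3 to compound 4 (within the scatter), within the scatter. The estimate for compound 4 is 10%, ranging from 0% to 35%.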

Compound 4, a percentage reported as activity, at one concentration (the size of the read-out at that concentration, not a potency): -17.6%
Compound 4: the middle estimate sits 27.6 percentage points above what was measured; the measured number lies below the stated range.
By their numbers in this assay, from the lowest: compound 4; then compound 3; then compound 1; then compound 2.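

In this assay, chloro in place of hydrogen on an aromatic carbon, ortho to a trifluoromethyl group, gives a number 24 percentage points lower from compound 3 to compound 4 (beyond the scatter) and so strengthens the effect even though compound 3 already stood low. The 4-chloro-3-(trifluoromethyl)phenyl group of compound 4 also stands well apart from the simpler rings, with a number 86.1 percentage points lower from compound 2 to compound 4 (beyond the scatter) and with a number 72.9 percentage points lower from compound 1 to compound 4 (beyond the scatter) as the wider steps. Nothing at hand gives a reason for the chloro step.

The compounds shown leave open whether this stronger effect belongs to chloro itself or would also appear with fluoro, methyl, an amine or a carboxylic acid at the same place. They also leave open whether chloro would do the same on a ring without the trifluoromethyl group.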